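Notes on the ring exchange at the thiocarbonyl carbon

This account rests on a few compounds, and the source may have more. Where it says the series, first, only, none or still open, it means among the compounds named here.

Measured so far:
compound 1, `Cc1cccc(/C(N)=N/NC(=S)N2CCSCC2)n1`, 1400 nM
compound 2, `N/C(=N\NC(=S)N1CCSCC1)c1ccccn1`, 760 nM

Both numbers come from a functional assay on A-375 cells (Homo sapiens) for cytotoxicity, read by MTT assay, with a stated time of 72 h; a higher number here means a weaker inhibitor, a lower number a stronger inhibitor. Compound 1 has the highest of the two numbers; its nearest neighbour is compound 2, and the step of a 1.8-fold lower number from compound 1 to compound 2 (0.27 log units; within the scatter) puts only hydrogen in place of methyl on an aromatic carbon.

Compound 3, `Cc1cccc(/C(N)=N/NC(=S)N2CCCC2)n1`, is not yet measured. It differs from compound 1 in one place: pyrrolidin-1-yl in place of thiomorpholin-4-yl on a thiocarbonyl carbon. Among the measured compounds shown here, neither measured compound varies the ring on the thiocarbonyl carbon; the only measured step, a 1.8-fold lower number from compound 1 to compound 2 (0.27 log units; within the scatter), concerns the aromatic methyl and lies within the scatter, so it carries no information on this exchange. For the measured compounds named here, with no comparable step in hand, no shift beyond the scatter can be argued for in either direction in this assay, and the range must stay wide.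

Compound 3 is therefore expected to sit close to compound 1. The estimate for compound 3 is 1400 nM, with a range of 450 nM to 4500 nM. This estimate means an expected step of no change at the digits printed from compound 1 to compound 3 (within the scatter), within the scatter.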

Compound 3, half-maximal inhibitory concentration: 2900 nM
For compound 3 the middle estimate is 2.1-fold (0.32 log units) below the measured one, and the stated range covers the measured number.
By their numbers in this assay, from the lowest: compounds 2 and 1 (each within the scatter of the next); then compound 3.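

Of the two single exchanges shown, only the one at the thiocarbonyl carbon leaves the scatter: in this assay pyrrolidin-1-yl in place of thiomorpholin-4-yl gives a 2.1-fold higher number from compound 1 to compound 3 (0.32 log units; beyond the scatter) as a modest step, while the exchange on the aromatic carbon gives a 1.8-fold lower number from compound 1 to compound 2 (0.27 log units; within the scatter) and stays within it. Among the compounds shown here, this position therefore responds to the choice of ring, and in the single pair available thiomorpholin-4-yl carries the lower number, although one pair sets no trend. The exchange replaces a six-membered ring holding sulfur with a five-membered ring without it, so ring size and the ring sulfur change together and this step cannot separate them, and the data at hand offer no measured basis for explaining the step.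

The compounds shown leave open which of the two changes carries the step, a question that piperidin-1-yl, a six-membered ring without sulfur, would address directly. Also open, from the compounds shown here alone, are whether the same exchange gives a step of similar size on compound 2, and how an open-chain diethylamino group would compare at this position.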